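From compound 1 to compound 3: one more double bond

This account rests on a few compounds, and the source may have more. Where it says the series, first, only, none or still open, it means among the compounds named here.

Compound 1 `C=C1CC[C@@H]2[C@](C)(CO)[C@H](O)CC[C@@]2(C)[C@]1(O)CCC1=CCOC1=O`: > 100000 nM (a limit, not a number)
Compound 2 `CO[C@]1(CO)CC[C@@H]2[C@](C)(CO)[C@H](O)CC[C@@]2(C)[C@@H]1CCC1=CCOC1=O`: > 100000 nM (a limit, not a number)

Both compounds were tested in a functional assay on RAW264.7 cells (Mus musculus) for inhibition, read by Griess assay, with a stated time of 24 h; a lower number here means a stronger inhibitor, a higher number a weaker inhibitor. Compound 1 stands at the limit of > 100000 nM in this assay, at which 2 of the 2 values shown sit. Among the compounds with values here, its true strength is therefore unknown, and no step between measured compounds is available as a guide.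

Compound 3 `C=C1CC[C@@H]2[C@](C)(CO)[C@H](O)CC[C@@]2(C)[C@]1(O)/C=C/C1=CCOC1=O` has not yet been measured. It differs from compound 1 in one group: a group of 8 heavy atoms (6 carbon, 2 oxygen; one five-membered non-aromatic ring with 1 hetero atom) in place of a group of 8 heavy atoms (6 carbon, 2 oxygen; one five-membered non-aromatic ring with 1 hetero atom), on a saturated ring carbon. The group that enters has one more double bond outside aromatic rings.

A modest gain in strength is expected, though the result could remain at the limit. The expected change is an at least 2.0-fold lower number from compound 1 to compound 3 (0.30 log units; that floor lies within the scatter). For compound 3 the estimated value is 50000 nM, with an expected range from 12000 nM to 100000 nM.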

Compound 3, half-maximal inhibitory concentration: 97200 nM
Compound 3: middle estimate off by 1.9-fold (0.29 log units), on the low side, and the stated range covers the measured number.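

Within the data shown here, compound 3 gives the first actual number in this assay: 97200 nM. Compound 1 has only a limit, not a number, at > 100000 nM. With one more double bond in the group on the saturated ring carbon, the step is an at least 1.0-fold lower number from compound 1 to compound 3 (0.01 log units; that floor lies within the scatter), so this change shows no gain that can be told apart from scatter.

From the compounds shown here alone, the true size of the step stays unknown, since it could be larger than this floor. Also open, going by these compounds, is whether an amine, a carboxylic acid or a longer chain in place of this group would give a clearly lower number.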